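The source may hold more compounds than are shown below. What is called first, only, known or untested is meant among the compounds shown, and "the series" means these compounds.

Measured so far:
compound 1, `CCCCCCCCCCCCNC(=O)[C@@H](NC(=O)c1cc2ccccc2o1)[C@@H](C)O`, 22900 nM
compound 2, `CCCCCCCCCCCCNC(=O)[C@@H](NC(=O)c1nccc2ccccc12)[C@@H](C)O`, 65700 nM
compound 3, `CCCCCCCCCCCCCCNC(=O)[C@@H](NC(=O)c1cc2ccccc2o1)[C@@H](C)O`, 23400 nM

These values come from a functional assay on HepG2 cells (Homo sapiens) for cytotoxicity, read by MTT assay, with a stated time of 48 h; on this read-out lower numbers stand for stronger inhibition and higher numbers for weaker inhibition. Compound 4, `CCCCCCCCCCCCCCNC(=O)[C@@H](NC(=O)c1nccc2ccccc12)[C@@H](C)O`, has not yet been measured there. Compound 4 differs from compound 3 by isoquinolin-1-yl in place of 1-benzofuran-2-yl on a carbonyl carbon. The same change, made once before among these compounds, gave a 2.9-fold higher number from compound 1 to compound 2 (0.46 log units; beyond the scatter). The two cores differ by ethyl in place of hydrogen on a saturated chain carbon, ten or more bonds along the chain from an amide-type nitrogen, a change that itself gave a 1.0-fold higher number from compound 1 to compound 3 (0.01 log units; within the scatter); the place of the ring swap reads the same in both cases, so it is the same change. Compound 4 is expected to show a 2.8-fold higher number from compound 3 to compound 4 (0.44 log units; beyond the scatter) because a 2.9-fold higher number from compound 1 to compound 2 (0.46 log units; beyond the scatter) and compound 3 gives 23400 nM, close to compound 1. Compound 4 is expected to give about 65000 nM, between 30000 nM and 140000 nM.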

Compound 4, half-maximal inhibitory concentration: 28600 nM
Estimate against measurement, compound 4: 2.3-fold (0.36 log units) above; the whole stated range lies above it.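

In this assay, the swap to isoquinolin-1-yl gave a 1.2-fold higher number from compound 3 to compound 4 (0.09 log units; within the scatter), and this step does not differ reliably from the earlier one: the same change on two cores in this assay, a 2.9-fold higher number (0.46 log units; beyond the scatter) from compound 1 to compound 2 and a 1.2-fold higher number (0.09 log units; within the scatter) from compound 3 to compound 4, 2.3-fold (0.37 log units) apart, within the scatter of two such steps. Adding ethyl in place of hydrogen on the chain gave a 2.3-fold lower number from compound 2 to compound 4 (0.36 log units; beyond the scatter), and this step likewise stays close to its counterpart: the same change on two cores in this assay, a 1.0-fold higher number (0.01 log units; within the scatter) from compound 1 to compound 3 and a 2.3-fold lower number (0.36 log units; beyond the scatter) from compound 2 to compound 4, 2.3-fold (0.37 log units) apart, within the scatter of two such steps. The swap thus reads beyond the scatter on one core and within it on the other, so these two pairs neither show that it carries over unchanged nor show that it depends on the core.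

The compounds shown leave open how a chain longer than that of compound 3, or a phenyl on the carbonyl carbon, would read in this assay.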